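Benzyl ester on the thiophene analogue: expected binding

The compounds below may be only part of what the source reports. "The series", "measured", "known", "first", "only" and "open" are said of these compounds alone.

Of the compounds shown here, three from one series have been measured in an assay on membranes from HEK293 cells for displacement of a labelled ligand from adenosine receptor A2b (Homo sapiens), read by scintillation counting, with a stated time of 30 min; on this read-out lower numbers stand for stronger inhibition and higher numbers for weaker inhibition. Compound 1 `CC1=C(C(=O)OCc2ccccc2)C(c2ccco2)NC(=O)N1` gives 887 nM. Within the data shown here, compound 2 `CC1=C(C(=O)OCc2ccccc2)C(c2ccoc2)NC(=O)N1`, which carries furan-3-yl in place of furan-2-yl on a saturated ring carbon, gives 6650 nM; the step of a 7.5-fold higher number from compound 1 to compound 2 (0.87 log units; beyond the scatter) is the only single-point change measured so far. Compound 3 `CCCOC(=O)C1=C(C)NC(=O)NC1c1cccs1` gives 1520 nM, the second highest of the three numbers: it lies within the scatter of compound 1 and well apart from compound 2.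

Compound 4 `CC1=C(C(=O)OCc2ccccc2)C(c2cccs2)NC(=O)N1` differs from compound 3 in one place: phenyl in place of ethyl on a saturated chain carbon bound to an oxygen next to a carbonyl group. Among the measured compounds shown here, no measured step concerns this part of the molecule, so the step from compound 1 to compound 2 does not bear on it directly. For the measured compounds named here, the only guidance is that compound 1, which already carries the benzyl ester, and compound 3, with the propyl ester, show values within the scatter of each other, although they also differ in the five-membered ring. On that basis no step beyond the scatter is expected. Compound 4 is therefore estimated at 1000 nM, with a range from 350 nM to 3000 nM. This corresponds to an expected 1.5-fold lower number from compound 3 to compound 4 (0.18 log units; within the scatter).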

Compound 4, inhibition constant: 1920 nM
Compound 4: the middle estimate sits 1.9-fold (0.28 log units) below what was measured; measured number inside the range.
By their numbers in this assay, from the lowest: compounds 1, 3 and 4 (each within the scatter of the next, the first and the last beyond it); then compound 2.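

In this assay, going from propyl to benzyl with the thiophen-2-yl group held fixed gives a 1.3-fold higher number from compound 3 to compound 4 (0.10 log units; within the scatter), so on this saturated chain carbon bound to an oxygen next to a carbonyl group, a chain and an aromatic ring read alike here, despite the printed gain in heavy atoms and the added ring. With the benzyl group held fixed, the group on the saturated ring carbon does separate the compounds: replacing furan-3-yl with thiophen-2-yl gives a 3.5-fold lower number from compound 2 to compound 4 (0.54 log units; beyond the scatter), while replacing furan-2-yl with thiophen-2-yl gives a 2.2-fold higher number from compound 1 to compound 4 (0.34 log units; beyond the scatter), which places the thiophen-2-yl compound apart from both furan compounds and on a scale set by the ring group rather than by the propyl-to-benzyl change. Nothing available explains either result.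

Among these compounds, still open is whether propyl and benzyl also read alike when furan-2-yl or furan-3-yl sits on the saturated ring carbon, as the one comparison at this position carries thiophen-2-yl. Also open, from the compounds shown here alone, is how a longer chain such as hexyl or a chain ending in an amine would read in place of benzyl, and how a phenyl group would read in place of thiophen-2-yl on the saturated ring carbon.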